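This account rests on a few compounds, and the source may have more. Where it says the series, first, only, none or still open, it means among the compounds named here.

Measured compounds:
compound 1 `COc1cc(NC(C)CCCNC(=O)Nc2cc(C(F)(F)F)cc(C(F)(F)F)c2)c2ncccc2c1` — 12000 nM
compound 2 `COc1cc(NC(C)CCCNC(=O)Nc2cccc(C(F)(F)F)c2)c2ncccc2c1` — 20000 nM
compound 3 `COc1cc(NC(C)CCCNC(=O)NNC(=O)Nc2cccc(C(F)(F)F)c2)c2ncccc2c1` — 36000 nM

All three numbers come from a functional assay on MOLT-4 cells (Homo sapiens) for inhibition, read by MTT assay, with a stated time of 72 h; on this read-out lower numbers stand for stronger inhibition and higher numbers for weaker inhibition. Compound 1 and compound 2 share a core and differ only by trifluoromethyl in place of hydrogen on an aromatic carbon; this change gave a 1.7-fold lower number from compound 2 to compound 1 (0.22 log units; within the scatter). Compound 3 stands highest of the three, and its gap to compound 2 is within the scatter while its gap to compound 1 is beyond it. The difference between the core of compound 3 and that of compound 2 is not broken down here.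

Compound 4 `COc1cc(NC(C)CCCNC(=O)NNC(=O)Nc2cc(C(F)(F)F)cc(C(F)(F)F)c2)c2ncccc2c1` is not yet measured in this assay . It differs from compound 3 by trifluoromethyl in place of hydrogen on an aromatic carbon, the same change as from compound 2 to compound 1, at a place described in the same words. The expected step is therefore a 1.7-fold lower number from compound 3 to compound 4 (0.23 log units; within the scatter), set beside the measured 1.7-fold lower number from compound 2 to compound 1 (0.22 log units; within the scatter) and resting on that single pair; one pair is a thin basis, so the range is kept wide. Compound 4 is thus estimated at 21000 nM, between 9000 nM and 50000 nM.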

Compound 4, half-maximal inhibitory concentration: 22000 nM
Compound 4: the middle estimate sits 1.0-fold (0.02 log units) below what was measured, within the range that was stated.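

In this assay, trifluoromethyl in place of hydrogen on an aromatic carbon gives a 1.6-fold lower number from compound 3 to compound 4 (0.21 log units; within the scatter), and the step carries from one core to the other with no difference that can be told apart: the same change on two cores in this assay, a 1.7-fold lower number (0.22 log units; within the scatter) from compound 2 to compound 1 and a 1.6-fold lower number (0.21 log units; within the scatter) from compound 3 to compound 4, 1.0-fold (0.01 log units) apart, within the scatter of two such steps. Both steps lie within the scatter; the agreement shows that the change stays small on both cores, but it does not establish a real effect of the change on either one. Two pairs at a place described in the same words also say nothing about other cores, other places on the ring, or how the change carries when a step stands clear of the scatter.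

From the compounds shown here alone, whether a nitrile or a carboxylic acid in place of the added trifluoromethyl would give a step beyond the scatter remains open. Also open, going by these compounds, is how a longer chain between the shared core and the urea-type linker would bear on the numbers in this assay, and whether this change would carry across such a chain.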